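The source may hold more compounds than are shown below. What is called first, only, known or untested is meant among the compounds shown, and "the series" means these compounds.

Series in a functional assay on NCI-N87 cells (Homo sapiens) for antiproliferative activity, read by CCK-8 assay, with a stated time of 72 h; a lower number here means a stronger inhibitor, a higher number a weaker inhibitor:
- compound 1 `Cc1cc(Nc2cc(N3CCN(C)CC3)nc(Nc3ccc([N+](=O)[O-])cc3)n2)n[nH]1`: 3880 nM
- compound 2 `Cc1cc(Nc2cc(N3CCN(C)CC3)nc(Nc3ccc(Cl)cc3)n2)n[nH]1`: 7470 nM
- compound 3 `Cc1cc(Nc2cc(N3CCN(C)CC3)nc(Nc3cccc([N+](=O)[O-])c3)n2)n[nH]1`: 4320 nM

These three values lie within the scatter of each other, so compound 1 holds no distinct place among them. Compound 4 `Cc1cc(Nc2cc(N3CCN(C)CC3)nc(Nc3cccc(Cl)c3)n2)n[nH]1` is still unmeasured and differs from compound 1 as follows: 3-chlorophenyl in place of 4-nitrophenyl on a nitrogen on an aromatic ring. In words, this is 3-chlorophenyl in place of 4-nitrophenyl on a nitrogen on an aromatic ring.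

For the measured compounds named here, two measured steps bear on it: a 1.9-fold higher number from compound 1 to compound 2 (0.28 log units; within the scatter), and a 1.1-fold higher number from compound 1 to compound 3 (0.05 log units; within the scatter). Both lie within the scatter, and compound 4 carries both changes at once. A small move towards a higher number is therefore expected, and the expected step is a 1.7-fold higher number from compound 1 to compound 4 (0.22 log units; within the scatter). For compound 4 the estimated value is 6500 nM, with an expected range of 3500 nM to 12000 nM.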

Compound 4, half-maximal inhibitory concentration: 1770 nM
The estimate for compound 4 lay 3.7-fold (0.56 log units) above the measured number; the whole stated range lies above it.
By their numbers in this assay, from the lowest: compound 4; then compounds 1, 3 and 2 (each within the scatter of the next).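

For the compounds shown here, the 3-chlorophenyl group gives the first steps beyond the scatter: a 2.2-fold lower number from compound 1 to compound 4 (0.34 log units; beyond the scatter) and a 4.2-fold lower number from compound 2 to compound 4 (0.63 log units; beyond the scatter). Where the group sits on the ring matters for chloro, whereas the two nitro compounds stayed within the scatter, a 1.1-fold higher number from compound 1 to compound 3 (0.05 log units; within the scatter). Chloro in place of nitro gives a 2.4-fold lower number from compound 3 to compound 4 (0.39 log units; beyond the scatter), so the outcome of that change depends on the ring position it is made at: the same change on two cores in this assay, a 1.9-fold higher number (0.28 log units; within the scatter) from compound 1 to compound 2 and a 2.4-fold lower number (0.39 log units; beyond the scatter) from compound 3 to compound 4, 4.7-fold (0.67 log units) apart, beyond the scatter of two such steps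

Whether this holds beyond chloro is open, for example with fluoro, methoxy or trifluoromethyl on the same ring. From the compounds shown here alone, the effect of a carboxylic acid or an amine there also remains unknown.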